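Nitro for acetamido on the aminophenyl side

The source may hold more compounds than are shown below. What is called first, only, known or untested is meant among the compounds shown, and "the series" means these compounds.

Measured so far:
compound 1 `COc1cc(OC)c(/C=C/S(=O)(=O)Cc2ccc(OC)c(N)c2)c(OC)c1` — < 10 nM
compound 2 `COc1ccc(CS(=O)(=O)/C=C/c2c(OC)cccc2OC)cc1[N+](=O)[O-]` — 10200 nM
compound 3 `COc1cc(OC)c(/C=C/S(=O)(=O)Cc2ccc(OC)c(NC(C)=O)c2)c(OC)c1` — 150 nM

In a functional assay on HCT-116 cells (Homo sapiens) for cytotoxicity, read by MTT assay, with a stated time of 72 h (a lower number here means a stronger inhibitor of growth, a higher number a weaker inhibitor of growth), compound 3 gives 150 nM, the lowest of the two numbers shown. For compound 1 the value < 10 nM is a limit of the assay, not a number (the limit of < 10 nM in this assay, at which 1 of the 3 values shown sits). Compound 2, on a different core, gives 10200 nM.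

Compound 4 `COc1cc(OC)c(/C=C/S(=O)(=O)Cc2ccc(OC)c([N+](=O)[O-])c2)c(OC)c1` differs from compound 3 by nitro in place of acetamido on an aromatic carbon. Among the measured compounds shown here, the only single-place step measured, an at least 15-fold higher number from compound 1 to compound 3 (1.17 log units; beyond the scatter), shows how strongly this position responds to change. Compound 2, carrying the same nitro group on another core, sits far weaker than compound 3. A substantial loss is therefore expected for compound 4 in this assay, of about a 10-fold higher number from compound 3 to compound 4 (1.00 log units; beyond the scatter). Compound 4 is estimated at 1500 nM, between 300 nM and 8000 nM.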

Compound 4, concentration for 50% growth inhibition: 660 nM
Compound 4: the middle estimate sits 2.3-fold (0.36 log units) above what was measured; the measured number falls inside the stated range.
By their numbers in this assay, from the lowest: compound 3; then compound 4; then compound 2. At a limit, below all of these: compound 1.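

In this assay, nitro in place of acetamido is a modest step, a 4.4-fold higher number from compound 3 to compound 4 (0.64 log units; beyond the scatter), while nitro in place of amino is a large one, an at least 66-fold higher number from compound 1 to compound 4 (1.81 log units; beyond the scatter), so on the shared core this position orders amino, then acetamido, then nitro. Compound 1 stands at a limit, not a number: the limit of < 10 nM in this assay, at which 1 of the 4 values shown sits.
With nitro held fixed, methoxy in place of hydrogen on an aromatic carbon also matters strongly, a 15-fold lower number from compound 2 to compound 4 (1.19 log units; beyond the scatter), so the nitro group alone does not set the weak value of compound 2.

As far as these compounds go, whether a methylamino, dimethylamino or hydroxyl group at this position would hold the level of the amino group stays open. How far any such group falls short of compound 1 cannot be sized while its value remains a limit.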